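A few compounds are considered here, and "the series" means these few. Any claim that something is new, unique, unknown or untested is made for them only; others in the source may bear on it.

Measured so far:
- compound 1 `COc1ccc(C(=O)n2c(-c3cn(C)c4ccccc34)nc3ccccc32)cc1OC`: 3100 nM
- compound 2 `Cn1cc(-c2nc3ccccc3n2C(=O)c2cccc(Br)c2)c2ccccc21`: 34200 nM

In a functional assay on A549 cells (Homo sapiens) for inhibition, read by MTT assay, with a stated time of 24 h (a lower number here means a stronger inhibitor of growth, a higher number a weaker inhibitor of growth), compound 1 holds the lower of the two numbers. Compound 3 `COc1ccc(C(=O)n2c(-c3cn(C)c4ccc(Br)cc34)nc3ccccc32)cc1OC` keeps the 3,4-dimethoxyphenyl on the carbonyl carbon and differs from compound 1 at one place: bromo in place of hydrogen on an aromatic carbon. Among the measured compounds shown here, the only measured step, an 11-fold higher number from compound 1 to compound 2 (1.04 log units; beyond the scatter), is large and beyond the scatter. It bears on this change only indirectly, since it swaps the group on the carbonyl carbon and leaves untouched the ring that takes the bromo in compound 3. For the measured compounds named here, no measured step covers a substitution on that ring, so the expectation remains loose. The expected change is small, with a slight lean towards a higher number and nothing beyond the scatter: a 1.3-fold higher number from compound 1 to compound 3 (0.11 log units; within the scatter). For compound 3 the estimated value is 4000 nM, with an expected range from 1200 nM to 14000 nM.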

Compound 3, concentration for 50% growth inhibition: 3400 nM
Compound 3: the middle estimate sits 1.2-fold (0.07 log units) above what was measured, within the range that was stated.
By their numbers in this assay, from the lowest: compounds 1 and 3 (each within the scatter of the next); then compound 2.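

In this assay, bromo in place of hydrogen on an aromatic carbon of the fused two-ring system gives a 1.1-fold higher number from compound 1 to compound 3 (0.04 log units; within the scatter), so compound 1 and compound 3 cannot be told apart here, and this position accepts one bromine atom without a shift beyond the scatter. Among the compounds shown here, this is the first measured step on that ring, and it contrasts with an 11-fold higher number from compound 1 to compound 2 (1.04 log units; beyond the scatter), the only step beyond the scatter, which lies in the group on the carbonyl carbon. No measurement at hand accounts for either outcome.

Going by these compounds, whether an amine or a carboxylic acid on the same aromatic carbon would also stay within the scatter remains open, since one bromo says nothing about groups of other kinds. Also open, on these data alone, is whether bromo at this position would read the same alongside the 3-bromophenyl of compound 2.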